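A Hydroxy for a Methyl on a Limit-Bound Hydrazone

This account rests on a few compounds, and the source may have more. Where it says the series, first, only, none or still open, it means among the compounds named here.

Compound 3 `Cc1ccc(C(=O)N/N=C/c2cc(I)c(O)c(I)c2)cc1` carries a methyl on its outer aromatic ring and shows, in a functional assay on HepG2 cells (Homo sapiens) for cytotoxicity, with a stated time of 24 h (a lower number here means a stronger inhibitor, a higher number a weaker inhibitor), no readable number. In this assay compound 3 reaches only the limit > 100000 nM; this is a bound of the measurement, not a value, and it is the point described by the limit of > 100000 nM in this assay, at which 1 of the 3 values shown sits. Compound 1 `Cc1ccc(C(=O)N/N=C/c2cc(I)cc(I)c2O)cc1`, a close relative, is likewise at a limit in this assay, > 25000 nM. Compound 2 `COc1ccc(C(=O)N/N=C/c2cc(I)cc(I)c2O)cc1` is the methoxy analogue of compound 1. In this assay compound 2 gives 45200 nM. Among the measured compounds shown here, the only measured single change, a step that the limit leaves unreadable from compound 1 to compound 2, concerns the same outer ring as the change now considered but cannot be sized because compound 1 stands at the limit of > 25000 nM in this assay, at which 1 of the 3 values shown sits.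

Compound 4 `O=C(N/N=C/c1cc(I)c(O)c(I)c1)c1ccc(O)cc1` is compound 3 with hydroxy in place of methyl on an aromatic carbon. No measured step reports a hydroxy entering for a methyl, so nothing shown here gives a direction beyond the scatter for this assay. With compound 3 at a limit, compound 4 is expected to remain near that limit, with the step of a number no higher from compound 3 to compound 4 (the limit leaves the size open) read as no change beyond the scatter. Compound 4 is therefore estimated at 100000 nM, between 40000 nM and 250000 nM, and most likely reported again only as a limit.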

Compound 4, half-maximal inhibitory concentration: 110000 nM
Compound 4: the middle estimate sits 1.1-fold (0.04 log units) below what was measured, within the range that was stated.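

In this assay compound 3 reaches only a limit, > 100000 nM, which is not a number. Compound 4 gives 110000 nM, so no size can be read for the step between compound 3 and compound 4. The compounds shown leave open whether hydroxy in place of methyl on this outer ring changes the result in this assay at all.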